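The source may report more compounds than this note shows. Statements on the series, on what has been measured and on what is new or still open speak of the compounds shown alone.

Two thiourea compounds bearing a trifluoromethyl group on an aromatic ring have been tested for harm to cells. In an ADME assay on MDBK cells (Bos taurus) for cytotoxicity, read by MTT assay, with a stated time of 96 h (on this read-out lower numbers stand for higher toxicity in this test and higher numbers for lower toxicity in this test), compound 1 `Cc1ccc(NC(=S)Nc2cccc(C(F)(F)F)c2)cc1Cl` gives 10000 nM, and compound 2 `O=C(NC(=S)Nc1cccc(C(F)(F)F)c1)[C@H]1C[C@@H]2CC[C@H]1C2` gives 10000 nM, so the two stand level within the usual scatter. Compound 3 `CC(=O)NC(=S)Nc1cccc(C(F)(F)F)c1` is the next to be measured. Relative to compound 2 the change is one carbon atom in place of a group of 7 heavy atoms (7 carbon; 2 five-membered non-aromatic rings of carbon only), on a carbonyl carbon. Within the data shown here, with no measured step of this kind to lean on, the expected step from compound 2 to compound 3 in this assay is no change at the digits printed from compound 2 to compound 3 (within the scatter), meaning no change beyond the scatter. Compound 3 is therefore estimated at 10000 nM, within a range from 5000 nM to 20000 nM.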

Compound 3, half-maximal cytotoxic concentration: > 100000 nM
Compound 3: only a limit was reported; the forecaster's own chance of this, stated with the estimate: 30%; at least 10-fold (1.00 log units) between middle value and limit.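

In this assay, the group on the carbonyl carbon proves to matter: one carbon atom, a methyl, in place of the group of 7 heavy atoms with its 2 five-membered rings gives an at least 10-fold higher number from compound 2 to compound 3 (1.00 log units; beyond the scatter). A higher number here means lower toxicity in this test. For compound 3 the result is a limit and not a number: the limit of > 100000 nM in this assay, at which 1 of the 3 values shown sits.

The compounds shown leave open how much size alone counts, since only this one replacement can be read. An ethyl group, a longer chain or a single five-membered carbon ring could show where the change sets in.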